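Replacing a chloro with a basic side chain on the distal ring

The source may report more compounds than this note shows. Statements on the series, on what has been measured and on what is new or still open speak of the compounds shown alone.

Compound 1 `O=C(O)CCc1ccc(NCc2ccc(Cl)cc2)cc1` is the weaker of two measured compounds in a functional assay for agonist activity at Free fatty acid receptor 1 (Homo sapiens); on this read-out lower numbers stand for an effect already at smaller amounts and higher numbers for an effect only at larger amounts of compound: compound 1 gives 1000 nM, while compound 2 `O=C(O)CCc1ccc(NCc2ccc(Cl)c(Cl)c2)cc1` gives 251 nM, and the one step shown, a 4.0-fold lower number from compound 1 to compound 2 (0.60 log units; beyond the scatter), is described as a chloro in place of hydrogen on an aromatic carbon. Compound 3 `CN(C)Cc1ccc(CNc2ccc(CCC(=O)O)cc2)cc1` has not yet been measured. It differs from compound 1 in one place: (dimethylamino)methyl in place of chloro on an aromatic carbon. Going by the values given here, no measured step covers this exchange; the step from compound 1 to compound 2 only shows that a further small substituent on that ring is tolerated with a modest gain, and it tells nothing about removing the chloro or about a (dimethylamino)methyl group. With so little to lean on, the expected change is small and uncertain: a step of a 1.6-fold higher number from compound 1 to compound 3 (0.20 log units; within the scatter) is estimated, leaning slightly toward a higher number, because the chloro present in compound 1 at 1000 nM is lost. Compound 3 is therefore expected to give about 1600 nM in this assay, with a plausible range from 400 nM to 6000 nM.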

Compound 3, half-maximal effective concentration: < 31700 nM
Compound 3 gave a limit, no number; the forecaster's own chance of this, stated with the estimate: 15%; the middle value is on the limit's open side.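

In this assay compound 3 gives < 31700 nM, which is a limit and not a number. The step between compound 1 and compound 3 therefore cannot be read. The compounds shown leave open whether (dimethylamino)methyl in place of chloro on an aromatic carbon raises, lowers or leaves unchanged the number seen for compound 1.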